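Replacing One Phenyl Group on Compound 1

A few compounds are considered here, and "the series" means these few. Any claim that something is new, unique, unknown or untested is made for them only; others in the source may bear on it.

Among the compounds with values here, in a functional assay on HeLa cells (Homo sapiens) for antiproliferative activity, read by spectrophotometry, with a stated time of 2 days (on this read-out lower numbers stand for stronger inhibition of growth and higher numbers for weaker inhibition of growth), compound 1 `COc1ccc(C(F)(F)F)cc1Nc1ncc(C(F)(F)F)c(N2Cc3cccc(N(C)S(C)(=O)=O)c3C2)n1` gives 17200 nM as the higher of the two numbers known so far. The core of compound 1 is shared by compound 2 `CN(c1cccc2c1CN(c1nc(Nc3cccc(Oc4ccccc4)c3)ncc1C(F)(F)F)C2)S(C)(=O)=O`, and in this assay compound 2 gives 4300 nM, a lower number by more than the usual scatter. The next compound to consider is compound 3 `CN(c1cccc2c1CN(c1nc(Nc3ccc(C(F)(F)F)cc3)ncc1C(F)(F)F)C2)S(C)(=O)=O`, which carries 4-(trifluoromethyl)phenyl in place of 2-methoxy-5-(trifluoromethyl)phenyl on a nitrogen on an aromatic ring. Within the data shown here, no measured pair isolates this change, so its size is uncertain. Compound 2, with 4300 nM from another group on that nitrogen, suggests that compound 1 need not be the best case. The expected step, an estimate only, is modest at a 2.2-fold lower number from compound 1 to compound 3 (0.33 log units; beyond the scatter) and points toward stronger inhibition of growth. For compound 3 the estimated value is 8000 nM with an expected range from 2500 nM to 20000 nM in this estimate.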

Compound 3, concentration for 50% growth inhibition: > 30000 nM
Compound 3: a limit, no number; the forecaster's own chance of this, stated with the estimate: 10%; at least 3.7-fold (0.57 log units) between middle value and limit.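

In this assay compound 3 sits at a limit of the assay and has no number: the limit of > 30000 nM in this assay, at which 1 of the 3 values shown sits. Read as a change, this is an at least 1.7-fold higher number from compound 1 to compound 3 (0.24 log units; that floor lies within the scatter), so the floor of the step does not separate the two compounds, although the real gap may be larger. What is new is that a group on this nitrogen can fail to give a lower number than compound 1, so a lower number is not a general result of changing this group.

This single swap cannot tell whether taking away the methoxy or shifting the trifluoromethyl matters more. From the compounds shown here alone, how a phenyl group bearing an amine or a carboxylic acid would read on this nitrogen in this assay also stays open.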